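The source may hold more compounds than are shown below. What is called first, only, known or untested is meant among the compounds shown, and "the series" means these compounds.

Measured compounds in a functional assay on HeLa cells (Homo sapiens) for cytotoxicity, read by MTT assay, with a stated time of 2 days, tested at 100 uM; a higher number here means a weaker effect of the compound at the concentration tested, a lower number a stronger effect:

Compound 1 `COc1ccc(-c2cc(C(C)=O)c3[nH]c(-c4ccccc4)cc3c2)cc1` gives 21.1% in this assay.
Compound 2 `COc1ccc(-c2cc(C(C)=O)c3[nH]c(-c4ccc(F)cc4)cc3c2)cc1` gives 20.6% in this assay.
Compound 3 `COc1ccc(-c2cc3cc(-c4ccccc4)cc(C(C)=O)c3[nH]2)cc1` gives 32.8% in this assay.

Compound 1 and compound 2 differ by fluoro in place of hydrogen on an aromatic carbon; this change made a number 0.5 percentage points lower from compound 1 to compound 2 (within the scatter). Compound 3 has the same atoms as compound 1 joined differently; the difference between the two cores is not broken down here. Compound 3 stands highest of the three in this assay, beyond the scatter from both compound 1 and compound 2.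

Compound 4 `COc1ccc(-c2cc3cc(-c4ccc(F)cc4)cc(C(C)=O)c3[nH]2)cc1` is not yet measured. It differs from compound 3 by fluoro in place of hydrogen on an aromatic carbon, the same change as from compound 1 to compound 2, at the same place. Because a number 0.5 percentage points lower from compound 1 to compound 2 (within the scatter) lay within the scatter, a step of similar size is expected, a number 0.8 percentage points lower from compound 3 to compound 4 (within the scatter). For compound 4 the estimate in this assay is 32%, expected between 22% and 42%.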

Compound 4, a percentage reported as activity, at one concentration (the size of the read-out at that concentration, not a potency): 46.5%
For compound 4 the middle estimate is 14.5 percentage points below the measured one; measured number outside the range, above it.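

In this assay, fluoro in place of hydrogen on an aromatic carbon gives a number 13.7 percentage points higher from compound 3 to compound 4 (beyond the scatter), which here means a weaker effect at the concentration tested. The change therefore does not carry over with the same size from one core to the other: the same change on two cores in this assay, a number 0.5 percentage points lower (within the scatter) from compound 1 to compound 2 and a number 13.7 percentage points higher (beyond the scatter) from compound 3 to compound 4, 14.2 percentage points apart, beyond the scatter of two such steps

This rests on a single pair per core at one concentration, so it shows that the step depends on the core for these four compounds, but it does not show why or whether other changes behave the same way. Open, from the compounds shown here alone, is whether chloro, an amine or a carboxylic acid in place of fluoro would also give different steps on the two cores. Also open, going by these compounds, is how either core responds when the acetyl group gives way to an amide.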